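Pyrrole for Pyrazole on an Adrenergic Agonist Core

The source may report more compounds than this note shows. Statements on the series, on what has been measured and on what is new or still open speak of the compounds shown alone.

Compound 1 `Cn1nccc1-c1ccccc1NCC1=NCCN1` is the reference point of this small set. In an in vitro functional assay on cells (Fibroblast) for agonist activity at Alpha-1A adrenergic receptor (Homo sapiens) (on this read-out lower numbers stand for an effect already at smaller amounts and higher numbers for an effect only at larger amounts of compound), compound 1 gives 10 nM, the lowest number among the three measured compounds and beyond the scatter from both of the others, so it is the most potent of the three. Compound 2 `CCn1ccc(-c2ccccc2NCC2=NCCN2)n1` gives 25.1 nM, and compound 3 `CCn1nccc1-c1ccccc1NCC1=NCCN1` gives 63.1 nM. Among the compounds with values here, the only single-point step among the measured compounds is a 6.3-fold higher number from compound 1 to compound 3 (0.80 log units; beyond the scatter), a methyl in place of hydrogen on a saturated chain carbon bound to an aromatic nitrogen, and it shows that even a small change at the five-membered ring can move the number noticeably.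

Compound 4 `Cn1cccc1-c1ccccc1NCC1=NCCN1` has not yet been measured. It differs from compound 1 as follows: 1-methyl-1H-pyrrol-2-yl in place of 1-methyl-1H-pyrazol-5-yl on an aromatic carbon. Within the data shown here, no measured step bears directly on this exchange of one five-membered ring for another; the step from compound 1 to compound 3 altered only the chain on the aromatic nitrogen, and compound 2 carries its ring in a different arrangement rather than a different ring. Given how a small change at this position moved the number before, a modest step is expected, most likely toward a higher number. For compound 4 the expected value is 25 nM, with a range from 6 nM to 100 nM, which corresponds to an estimated step of a 2.5-fold higher number from compound 1 to compound 4 (0.40 log units; beyond the scatter).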

Compound 4, half-maximal effective concentration: 20 nM
For compound 4 the middle estimate is 1.3-fold (0.10 log units) above the measured one; low and high end bracket the measured number.
By their numbers in this assay, from the lowest: compounds 1, 4 and 2 (each within the scatter of the next, the first and the last beyond it); then compound 3.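

In this assay, within the data shown here, replacing the 1-methyl-1H-pyrazol-5-yl group with 1-methyl-1H-pyrrol-2-yl on the aromatic carbon of the six-membered ring gives a 2.0-fold higher number from compound 1 to compound 4 (0.30 log units; within the scatter), the first direct reading of an exchange of the five-membered ring itself. The entering ring has 1 hetero atom and 1 hydrogen-bond acceptor where the leaving ring has 2 of each, so at this place, in this one pair, the second ring nitrogen can be exchanged for carbon without a step beyond the scatter, whereas the step on the chain at the aromatic nitrogen, a 6.3-fold higher number from compound 1 to compound 3 (0.80 log units; beyond the scatter), lies beyond it. Nothing shown explains why the two steps are read differently.

The compounds shown leave open whether a thiophene or a phenyl ring at this same place would also stay within the scatter of compound 1, since only two five-membered nitrogen rings with a methyl group can be compared here. They also leave open whether 1-ethyl-1H-pyrrol-2-yl would repeat on the pyrrole the step that the ethyl group gave on the pyrazole.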